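The source may report more compounds than this note shows. Statements on the series, on what has been measured and on what is new or still open speak of the compounds shown alone.

Measured in a functional assay on Gurav cells (Homo sapiens) for inhibition, read by sulforhodamine B assay; a higher number here means a weaker inhibitor of growth, a lower number a stronger inhibitor of growth:
- compound 1 `c1ccc(-c2ccc(-c3ccc(-c4nc5ccccc5[nH]4)cc3)cc2)cc1`: 100000 nM
- compound 2 `Cc1ccc2[nH]c(-c3ccc(-c4ccc(-c5cccc(Cl)c5)cc4)cc3)nc2c1`: 2120 nM
- compound 3 `COc1cc(-c2ccc(-c3ccc(-c4nc5cc(C)ccc5[nH]4)cc3)cc2)cc(OC)c1OC`: 170 nM

Not yet measured: compound 4 `Oc1ccc(-c2ccc(-c3ccc(-c4nc5ccccc5[nH]4)cc3)cc2)cc1`

Compound 1 has the highest number of the three, 100000 nM, which makes it the weakest growth inhibitor in this small set. Compound 2 and compound 3 both lie far lower, beyond the scatter.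

Compound 4 keeps the core of compound 1 and turns phenyl into 4-hydroxyphenyl, with hydroxy in place of hydrogen on an aromatic carbon, para to a large group: hydroxy in place of hydrogen on an aromatic carbon.

For the measured compounds named here, no measured pair differs in one place only, so the size of this change has no direct precedent. Compound 2, at 2120 nM, and compound 3, at 170 nM, carry substituents on the ring that changes in compound 4, but each also differs from compound 1 elsewhere. They therefore hint at a direction only.

In this assay a lower number is expected, with a drop beyond the scatter but short of those gaps, estimated as an 8.3-fold lower number from compound 1 to compound 4 (0.92 log units; beyond the scatter). For compound 4 the estimated value is 12000 nM, with an expected range of 2000 nM to 70000 nM.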

Compound 4, concentration for 50% growth inhibition: 100000 nM
For compound 4 the middle estimate is 8.3-fold (0.92 log units) below the measured one; the whole stated range lies below it.
By their numbers in this assay, from the lowest: compound 3; then compound 2; then compounds 1 and 4 (each within the scatter of the next).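

In this assay, hydroxy in place of hydrogen on an aromatic carbon, para to a large group, gives no change at the digits printed from compound 1 to compound 4 (within the scatter). For the compounds shown here, this is the first reading of a single change at this position: on the core of compound 1, phenyl to 4-hydroxyphenyl does not separate compound 4 from compound 1. No supporting data bear on why the step reads this way.

The compounds shown leave open whether another group at this same place, such as an amine or a carboxylic acid, would give a step beyond the scatter. Also open, as far as these compounds go, is whether hydroxy would give the same step when added to a compound with a lower starting number, such as compound 2 at 2120 nM.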